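The source may hold more compounds than are shown below. What is called first, only, known or untested is meant among the compounds shown, and "the series" means these compounds.

Measured so far:
compound 1 `C/C(=C1/OC(=O)NC1=O)C(c1ccc(-c2ccc3cccc(F)c3c2)[nH]c1=O)C(C)C`, 17 nM
compound 2 `CCC(CC)C(/C=C1\OC(=O)NC1=O)c1ccc(-c2ccc3cccc(F)c3c2)[nH]c1=O`, 13 nM
compound 3 `CCC(/C=C1\OC(=O)NC1=O)(CC)c1ccc(-c2ccc3c(c2)OC(C)(C)CC3)[nH]c1=O`, 2600 nM

All three were tested in an assay on membranes from Chem-1 cells for displacement of a labelled ligand from prostaglandin E2 receptor EP3 subtype (Homo sapiens), read by scintillation counting, with a stated time of 2 h; a lower number here means a stronger inhibitor, a higher number a weaker inhibitor. Compound 1 gives 17 nM there, the second highest of the three numbers. Its nearest neighbour is compound 2 at 13 nM, a gap that lies within the usual scatter, so the two cannot be told apart. Compound 3, at 2600 nM, is far weaker, and that gap lies well beyond the scatter.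

Compound 4 `CC(C)C(/C=C1\SC(=O)NC1=O)c1ccc(-c2ccc3cccc(F)c3c2)[nH]c1=O` has not been measured. It differs from compound 1 in one place: a group of 8 heavy atoms (4 carbon, 1 nitrogen, 2 oxygen, 1 sulfur; one five-membered non-aromatic ring with 2 hetero atoms) in place of a group of 9 heavy atoms (5 carbon, 1 nitrogen, 3 oxygen; one five-membered non-aromatic ring with 2 hetero atoms), on a saturated chain carbon bound to an aromatic carbon and a saturated chain carbon. The change is modest in size and keeps the ring with its donor and acceptors, so no large shift is expected. Since the bicyclic end of compound 1 is also carried by compound 2, which gives 13 nM, this part of the series appears to tolerate small variation. The step from compound 1 to compound 4 in this assay is expected to be small, a 1.2-fold higher number from compound 1 to compound 4 (0.07 log units; within the scatter), in either direction or none beyond the scatter. Compound 4 is therefore estimated at 20 nM, within a range of 6 nM to 70 nM.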

Compound 4, inhibition constant: 13 nM
For compound 4 the middle estimate is 1.5-fold (0.19 log units) above the measured one; the range from low to high includes it.
By their numbers in this assay, from the lowest: compounds 2, 4 and 1 (each within the scatter of the next); then compound 3.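

In this assay, putting a group of 8 heavy atoms with one sulfur in place of a group of 9 heavy atoms with three oxygens gives a 1.3-fold lower number from compound 1 to compound 4 (0.12 log units; within the scatter), so the two compounds cannot be told apart. Among the compounds shown here, this is the first direct comparison at this place, a saturated chain carbon bound to an aromatic carbon and a saturated chain carbon, and it shows that binding in this assay survives this exchange of one five-membered non-aromatic ring with 2 hetero atoms for another. No measurement here explains this result.

One exchange says little about how much variation this place allows. The compounds shown leave open whether any such ring is needed at all, or whether a simple carboxylic acid could stand in its place.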